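Thiazole acetic acids as prostaglandin D2 receptor 2 antagonists

This account rests on a few compounds, and the source may have more. Where it says the series, first, only, none or still open, it means among the compounds named here.

Measured so far:
- compound 1, `Nc1nc(-c2ccc(Cl)cc2)c(CC(=O)O)s1`: in an in vitro functional assay on HEK285-7 cells for antagonist activity at prostaglandin D2 receptor 2 (Homo sapiens), read by BRET and beta-arrestin recruitment (on this read-out lower numbers stand for stronger inhibition and higher numbers for weaker inhibition), compound 1 gives only a limit, > 100000 nM.
- compound 2, `O=C(O)Cc1sc(C(c2ccc(F)cc2)c2ccc(F)cc2)nc1-c1cc(F)cc(F)c1`: in this assay compound 2 gives 340 nM.

Going by the values given here, compound 2 holds the only number; the other value shown is the limit of > 100000 nM in this assay, at which 1 of the 2 values shown sits. Compound 3, `COc1cc(-c2nc(C(c3ccc(F)cc3)c3ccc(F)cc3)sc2CC(=O)O)ccn1`, carries 2-methoxypyridin-4-yl in place of 3,5-difluorophenyl on an aromatic carbon. Among the compounds with values here, no measured step covers this change, so the expectation for compound 3 is a step of a 1.5-fold higher number from compound 2 to compound 3 (0.17 log units; within the scatter), not beyond the scatter. The estimate for compound 3 in this assay is 500 nM, between 150 nM and 2000 nM.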

Compound 3, half-maximal inhibitory concentration: 380 nM
For compound 3 the middle estimate is 1.3-fold (0.12 log units) above the measured one; the measured number falls inside the stated range.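

In this assay, the swap of 3,5-difluorophenyl for 2-methoxypyridin-4-yl gives a 1.1-fold higher number from compound 2 to compound 3 (0.05 log units; within the scatter), the first step read at this position on an aromatic carbon next to the ring nitrogen. The position therefore takes a six-membered aromatic ring with 1 hetero atom and 2 hydrogen-bond acceptors in place of a carbon-only ring, with the two values within the scatter. Nothing measured in the series accounts for this result.

Open: whether the methoxy group and the pyridine nitrogen count separately here, and whether an amine or a carboxylic acid on this ring would hold the value.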